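Removing a nitrogen and a methyl from the sulfonyl arm

A few compounds are considered here, and "the series" means these few. Any claim that something is new, unique, unknown or untested is made for them only; others in the source may bear on it.

Measured compounds:
Compound 1, `CC[C@H](C)[C@H](NC(=O)c1cccc(Cn2ccnc2)c1)C(=O)Nc1nccs1`, gives 42000 nM in an assay on HEK293 cells for displacement of a labelled ligand from Type-2 angiotensin II receptor (Homo sapiens); on this read-out higher numbers stand for weaker inhibition and lower numbers for stronger inhibition.
Compound 2, `CC[C@H](C)[C@H](NC(=O)c1cccc(Cn2ccnc2)c1)C(=O)NNS(=O)(=O)c1ccccc1`, reaches only the limit of this assay at > 100000 nM.
Compound 3, `CC[C@H](C)[C@H](NC(=O)c1cccc(Cn2ccnc2)c1)C(=O)NNS(=O)(=O)c1ccc(C)cc1`, gives 29000 nM in this assay.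

Compound 3 holds the lowest of the two actual numbers, yet compound 1 sits within the scatter of it, so the two cannot be ranked; the third value is a limit, not a number. Compound 4, `CC[C@H](C)[C@H](NC(=O)c1cccc(Cn2ccnc2)c1)C(=O)NS(=O)(=O)c1ccccc1`, is not yet measured. It differs from compound 3 by phenylsulfonyl in place of ((4-methylphenyl)sulfonyl)amino on an amide-type nitrogen.

Going by the values given here, only one measured step bears on this change: an at least 3.4-fold lower number from compound 2 to compound 3 (0.53 log units; beyond the scatter). Compound 4 drops that methyl again, and in this respect it resembles compound 2, which reached only the limit. Among the compounds with values here, no measured step covers the loss of the hydrazide nitrogen, so that part of the change carries no evidence either way.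

The methyl-removal step alone points to a weaker binder, and the estimate therefore expects compound 4 at 70000 nM, within 20000 nM to 200000 nM, meaning a 2.4-fold higher number from compound 3 to compound 4 (0.38 log units; beyond the scatter).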

Compound 4, inhibition constant: 18000 nM
Compound 4: the middle estimate sits 3.9-fold (0.59 log units) above what was measured; measured number below the stated range.
By their numbers in this assay, from the lowest: compounds 4, 3 and 1 (each within the scatter of the next, the first and the last beyond it). At a limit, above all of these: compound 2.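

Phenylsulfonyl set directly on the amide-type nitrogen keeps binding in the range of the longer ((4-methylphenyl)sulfonyl)amino group, with a 1.6-fold lower number from compound 3 to compound 4 (0.21 log units; within the scatter), and the two cannot be ranked; yet it also gives a 2.3-fold lower number from compound 1 to compound 4 (0.37 log units; beyond the scatter), a separation from the 1,3-thiazol-2-yl compound that compound 3 did not reach. Without the methyl on either compound, removing only the amino nitrogen gives an at least 5.5-fold lower number from compound 2 to compound 4 (0.74 log units; beyond the scatter), so a ring lacking that methyl does not by itself mean weak binding. Compound 2 stands at a limit, not a number: the limit of > 100000 nM in this assay, at which 1 of the 4 values shown sits.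

Still open, as far as these compounds go, is whether adding a methyl to the ring of compound 4 would change its number, as it did from compound 2 to compound 3. Also open, from the compounds shown here alone, is whether a carboxylic acid or a tetrazole in place of phenylsulfonyl would retain binding.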